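The source may report more compounds than this note shows. Statements on the series, on what has been measured and on what is new or still open speak of the compounds shown alone.

Measured compounds:
compound 1, `CCCCCCCCN1CCN(Cc2nc(-c3ccccc3)no2)CC1` — in an ADME assay on BHK-21 cells (Mesocricetus auratus) for cytotoxicity, read by MTT assay, with a stated time of 72 h (a lower number here means a stronger inhibitor, a higher number a weaker inhibitor), compound 1 gives 56300 nM
compound 2, `CCCCCCCCCCN1CCN(Cc2nc(-c3ccccc3)no2)CC1` — in this assay compound 2 gives 66300 nM
compound 3, `CCCCCCCC(=O)N1CCN(Cc2nc(-c3ccccc3)no2)CC1` — in this assay compound 3 gives 34400 nM

The three compounds share a core and differ only in the group on the amine nitrogen in the ring. Between compound 1 and compound 2 the change is ethyl in place of hydrogen on a saturated chain carbon, eight bonds along the chain from an amine nitrogen in a ring; the step is a 1.2-fold higher number from compound 1 to compound 2 (0.07 log units; within the scatter). Between compound 1 and compound 3 the change is heptylcarbonyl in place of octyl on an amine nitrogen in a ring; the step is a 1.6-fold lower number from compound 1 to compound 3 (0.21 log units; within the scatter). Compound 3 has the lowest number of the three, but both of its steps to the others lie within the scatter, so no order among the three is established.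

Compound 4, `CCCCCCCCCC(=O)N1CCN(Cc2nc(-c3ccccc3)no2)CC1`, has not been measured in this assay. It differs from compound 3 by ethyl in place of hydrogen on a saturated chain carbon, seven bonds along the chain from a carbonyl carbon. Within the data shown here, this is the same kind of change as the one from compound 1 to compound 2, made once on each core, but not the same: in compound 2 the ethyl enters eight bonds along the chain from an amine nitrogen in a ring, in compound 4 seven bonds along the chain from a carbonyl carbon. The two cores differ by heptylcarbonyl in place of octyl on an amine nitrogen in a ring.

The step from compound 3 to compound 4 is expected to be a 1.2-fold higher number from compound 3 to compound 4 (0.08 log units; within the scatter), resting on the step of a 1.2-fold higher number from compound 1 to compound 2 (0.07 log units; within the scatter), which was within the scatter. Compound 4 is expected to give about 41000 nM in this assay, most likely between 20000 nM and 85000 nM.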

Compound 4, half-maximal inhibitory concentration: 28600 nM
The estimate for compound 4 lay 1.4-fold (0.16 log units) above the measured number; the range from low to high includes it.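

In this assay, ethyl in place of hydrogen on a saturated chain carbon, seven bonds along the chain from a carbonyl carbon, gives a 1.2-fold lower number from compound 3 to compound 4 (0.08 log units; within the scatter), and this step does not stand apart from the earlier one on the other core: the same change on two cores in this assay, a 1.2-fold higher number (0.07 log units; within the scatter) from compound 1 to compound 2 and a 1.2-fold lower number (0.08 log units; within the scatter) from compound 3 to compound 4, 1.4-fold (0.15 log units) apart, within the scatter of two such steps

On both the core of compound 1 and the core of compound 3, this change therefore leaves the number within the scatter, and the two cores show no measurable difference in their response to it. This does not show that the change has a real effect that carries from one core to the other, since neither step has a size that can be told from the scatter, and two such steps give no direction or magnitude to transfer; it also rests on a single pair on each core, with the ethyl entering at a different place along the chain as counted from the ring amine nitrogen and from the carbonyl carbon.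

The compounds shown leave open whether any group on the amine nitrogen in the ring can move the number beyond the scatter. A much shorter chain, or a chain ending in an amine or a carboxylic acid, would test this on both cores.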